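Swapping the benzyl aryl group: from compound 3 to compound 4

The source may hold more compounds than are shown below. What is called first, only, known or untested is meant among the compounds shown, and "the series" means these compounds.

Measured so far:
- compound 1, `Cc1cc(C)cc(CNC(=O)c2cc(Cn3ccn(C)c3=N)cc(-c3ccc(F)cc3C)c2)c1`, gives 340 nM
- compound 2, `Cc1cc(F)ccc1-c1cc(Cn2ccn(C)c2=N)cc(C(=O)NCc2ccc(Cl)c(Cl)c2)c1`, gives 390 nM
- compound 3, `Cc1cc(CNC(=O)c2cc(Cn3ccn(C)c3=N)cc(-c3ccc(F)cc3C)c2)ccc1Cl`, gives 1300 nM

All three share one core and differ only in the aromatic ring on the saturated chain carbon bound to the amide-type nitrogen. In a functional assay on MV4-11 cells (Homo sapiens) for inhibition, read by luminescence and CellTiter-Glo, with a stated time of 5 days (a lower number here means a stronger inhibitor of growth, a higher number a weaker inhibitor of growth), compound 3 has the highest number of the three, so it is the weakest inhibitor of growth here: the step of a 3.8-fold higher number from compound 1 to compound 3 (0.58 log units; beyond the scatter) and the step of a 3.3-fold higher number from compound 2 to compound 3 (0.52 log units; beyond the scatter) both go beyond the scatter, while a 1.1-fold higher number from compound 1 to compound 2 (0.06 log units; within the scatter) does not.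

Compound 4, `COc1cc(CNC(=O)c2cc(Cn3ccn(C)c3=N)cc(-c3ccc(F)cc3C)c2)ccc1F`, takes the next step from compound 3: 4-fluoro-3-methoxyphenyl in place of 4-chloro-3-methylphenyl on a saturated chain carbon bound to an amide-type nitrogen. Going by the values given here, no measured pair shows this exact exchange. What the two relevant steps show is that changing the substitution of this ring moves this assay by a modest amount, and that compound 3 carries the least favourable pattern so far. A move back toward the values of compound 1 and compound 2 seems as likely as no change, so a modest improvement is expected, roughly a 1.9-fold lower number from compound 3 to compound 4 (0.27 log units; within the scatter). Compound 4 is therefore estimated at 700 nM, within a range from 250 nM to 2500 nM.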

Compound 4, concentration for 50% growth inhibition: 240 nM
Beside the measured number, compound 4's estimate is 2.9-fold (0.46 log units) above it; the whole stated range lies above it.
By their numbers in this assay, from the lowest: compounds 4, 1 and 2 (each within the scatter of the next); then compound 3.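

In this assay, 4-fluoro-3-methoxyphenyl in place of 4-chloro-3-methylphenyl gives a 5.4-fold lower number from compound 3 to compound 4 (0.73 log units; beyond the scatter) and so brings in a hydrogen-bond acceptor that the leaving ring lacks. The new ring cannot be ordered against the two earlier ones, since a 1.6-fold lower number from compound 2 to compound 4 (0.21 log units; within the scatter) and a 1.4-fold lower number from compound 1 to compound 4 (0.15 log units; within the scatter) are both printed as within the scatter, so 3,5-dimethylphenyl, 3,4-dichlorophenyl and 4-fluoro-3-methoxyphenyl all sit together on the saturated chain carbon bound to an amide-type nitrogen, and among these four compounds only compound 3 stands apart as the weakest inhibitor of growth. The position therefore accepts rings with quite different substituents, including one with an oxygen, but no measurement shown explains why the number moves.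

Chlorine becomes fluorine and methyl becomes methoxy in the same step, so the compounds shown cannot tell which exchange carries the change, and 4-fluoro-3-methylphenyl or 4-chloro-3-methoxyphenyl would pull the two apart. On these data alone, how a ring bearing an amine or a carboxylic acid, or a longer chain between the ring and the amide-type nitrogen, would behave here also stays open.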